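Nitro-to-fluoro exchange across two diaminopyrimidine series

A few compounds are considered here, and "the series" means these few. Any claim that something is new, unique, unknown or untested is made for them only; others in the source may bear on it.

Values in a functional assay on CCRF-CEM cells (Homo sapiens) for cytotoxicity, in the presence of a further agent that is not named here (a lower number here means a stronger inhibitor, a higher number a weaker inhibitor), for the measured compounds:
compound 1 `Nc1nc(N)c(CCCN(Cc2ccc(NC(CCC(=O)O)C(=O)O)cc2)c2cc(F)c([N+](=O)[O-])cc2[N+](=O)[O-])c(O)n1`: 43000 nM
compound 2 `Nc1nc(N)c(CCCN(Cc2ccc(NC(CCC(=O)O)C(=O)O)cc2)c2cc(F)c(F)cc2[N+](=O)[O-])c(O)n1`: this value is a limit of the assay, > 100000 nM
compound 3 `Nc1nc(N)c(CCCNc2cc(F)c([N+](=O)[O-])cc2[N+](=O)[O-])c(O)n1`: 1200 nM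

Compound 1 and compound 2 share one core and differ by fluoro in place of nitro on an aromatic carbon. This change gives an at least 2.3-fold higher number from compound 1 to compound 2 (0.36 log units; beyond the scatter), a step bounded only by the limit of > 100000 nM in this assay, at which 1 of the 3 values shown sits. Compound 3 carries a different core; its difference from compound 1 is not broken down here. Among the measured compounds compound 3 has the lowest number in this assay.

Compound 4 `Nc1nc(N)c(CCCNc2cc(F)c(F)cc2[N+](=O)[O-])c(O)n1` is the analogue of compound 3 formed by fluoro in place of nitro on an aromatic carbon, the same change as from compound 1 to compound 2, made at an identically described place. Compound 4 is therefore expected to show a 5.0-fold higher number from compound 3 to compound 4 (0.70 log units; beyond the scatter) in this assay, a weakening of the same direction as an at least 2.3-fold higher number from compound 1 to compound 2 (0.36 log units; beyond the scatter), whose true size is not fixed by the measured pair. The estimate for compound 4 in this assay is 6000 nM, between 2000 nM and 30000 nM.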

Compound 4, half-maximal inhibitory concentration: 97000 nM
Beside the measured number, compound 4's estimate is 16-fold (1.21 log units) below it, outside the stated range (above it).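

In this assay, fluoro in place of nitro on an aromatic carbon gives an 81-fold higher number from compound 3 to compound 4 (1.91 log units; beyond the scatter), a large weakening on the core of compound 3. The change points the same way on both cores, so its direction carries over in these two pairs, but that does not show that its size carries over: the same change on two cores in this assay, an at least 2.3-fold higher number (0.36 log units; beyond the scatter) from compound 1 to compound 2 and an 81-fold higher number (1.91 log units; beyond the scatter) from compound 3 to compound 4; the limit leaves it open whether they differ. The value of compound 2, > 100000 nM, is a limit of the assay and not a number.

The two pairs leave open whether the steep loss belongs to fluoro itself or to the removal of nitro, since no other group, such as a nitrile or a methoxy group, stands at this place on either core. They also leave open what exchange of the remaining nitro group would do, and whether a longer chain in place of the three-carbon link between the two rings would alter the size of the step.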